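Ethoxy in place of methoxymethyl on a shared core

This account rests on a few compounds, and the source may have more. Where it says the series, first, only, none or still open, it means among the compounds named here.

Measured in an in vitro ADME assay on microsomes from liver (Mus musculus) for metabolic stability; a lower number here means slower removal, a higher number faster removal of the compound
- Compound 1 `COCc1nc2nc(C)cc(Nc3ccc(C(F)(F)F)cc3)n2n1` gives 13.3 mL.min-1.g-1
- Compound 2 `Cc1cc(Nc2ccc(S(F)(F)(F)(F)F)cc2)n2nc(C(F)(F)F)nc2n1` gives < 6 mL.min-1.g-1
- Compound 3 `Cc1cc(Nc2ccc(S(F)(F)(F)(F)F)cc2)n2nc(C3CC3)nc2n1` gives 12.6 mL.min-1.g-1

Compound 1 and compound 3 lie within the usual scatter of each other. Compound 2 reports only a limit (< 6 mL.min-1.g-1). Compound 4 `CCOc1nc2nc(C)cc(Nc3ccc(C(F)(F)F)cc3)n2n1` has the same atoms as compound 1, joined differently: ethoxy in place of methoxymethyl on an aromatic carbon. Among the compounds with values here, the one measured step that bears on this, cyclopropyl in place of trifluoromethyl on an aromatic carbon (an at least 2.1-fold higher number from compound 2 to compound 3 (0.32 log units; beyond the scatter)), exchanged different atoms, so no step beyond the scatter is expected here in this assay. The expected step is small (a 1.1-fold lower number from compound 1 to compound 4 (0.04 log units; within the scatter)). For compound 4 the estimated value is 12 mL.min-1.g-1 (estimated range 6 mL.min-1.g-1 to 26 mL.min-1.g-1).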

Compound 4, intrinsic clearance in microsomes: 14.4 mL.min-1.g-1
Compound 4: middle estimate off by 1.2-fold (0.08 log units), on the low side, within the range that was stated.
By their numbers in this assay, from the lowest: compounds 3, 1 and 4 (each within the scatter of the next). At a limit, below all of these: compound 2.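

In this assay, ethoxy in place of methoxymethyl gives a 1.1-fold higher number from compound 1 to compound 4 (0.03 log units; within the scatter) on this aromatic carbon, so the two compounds cannot be told apart here. The earlier step exchanged different atoms, whereas this one keeps the same atoms and only joins them differently, which leaves the read-out within the scatter at this position. Nothing measured here accounts for this outcome. Still open, from the compounds shown here alone, is whether an amine or a longer chain such as butoxy at this place would also stay within the scatter of compound 1.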